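A few compounds are considered here, and "the series" means these few. Any claim that something is new, unique, unknown or untested is made for them only; others in the source may bear on it.

Of the compounds shown here, three have been measured so far in a functional assay on PC-3 cells (Homo sapiens) for cytotoxicity, read by MTT assay, with a stated time of 48 h; on this read-out lower numbers stand for stronger inhibition and higher numbers for weaker inhibition. Compound 1 `CC1=NN(C(=O)CCc2ccccc2)C(c2cc(Br)cc(Br)c2O)C1` gives 11300 nM. Compound 2 `CC(=O)Oc1ccccc1C1CC(C)=NN1C(=O)CN1CCC(C(C)=O)CC1` gives 6800 nM. Compound 3 `CCC(=O)N1N=C(c2cc3ccccc3oc2=O)CC1c1ccccc1` gives 4370 nM, the lowest of the three numbers; its gap to compound 2 lies within the usual scatter of repeated measurements, while its gap to compound 1 lies beyond it.

Compound 4 `O=C(CNC1CCCCC1)N1N=C(c2cc3ccccc3oc2=O)CC1c1ccccc1` has not yet been tested. It keeps the core of compound 3 and differs from it in a single place: cyclohexylamino in place of methyl on a saturated chain carbon bound to a carbonyl carbon. For the measured compounds named here, none of the measured pairs shows this kind of exchange, so there is no measured step that could serve as a guide, and the three measured compounds differ from one another in several places at once. The expectation therefore rests on the small spread seen among the measured numbers and on the size of the change. In this assay the step is expected to be a 1.5-fold lower number from compound 3 to compound 4 (0.16 log units; within the scatter), a modest move toward a lower number that may still fall within the scatter. Compound 4 is accordingly estimated to give about 3000 nM, with a plausible range from 900 nM to 10000 nM.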

Compound 4, half-maximal inhibitory concentration: 48500 nM
Estimate against measurement, compound 4: 16-fold (1.21 log units) below; the whole stated range lies below it.
By their numbers in this assay, from the lowest: compounds 3, 2 and 1 (each within the scatter of the next, the first and the last beyond it); then compound 4.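

In this assay, cyclohexylamino in place of methyl on a saturated chain carbon bound to a carbonyl carbon gives an 11-fold higher number from compound 3 to compound 4 (1.05 log units; beyond the scatter). For the compounds shown here, this is the first single-place comparison, and it shows that a change at this one position can move the number by far more than the usual scatter, which the earlier compounds, differing in several places at once, could not show. The exchange brings in more heavy atoms, a six-membered carbon ring, a nitrogen, a hydrogen-bond donor and a hydrogen-bond acceptor all together, and no information shown here explains the result or separates the contributions of these features.

From the compounds shown here alone, it remains open which part of the new group goes with the higher number: a plain cyclohexyl group, which lacks the nitrogen, a small dimethylamino group, which lacks the carbon ring, and a morpholine ring at the same place would each help to tell these features apart. Going by these compounds alone, it is also open whether cyclohexylamino would have a similar effect on another core, such as the one carried by compound 1 or compound 2.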